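This account rests on a few compounds, and the source may have more. Where it says the series, first, only, none or still open, it means among the compounds named here.

Of the compounds shown here, three sharing one core have been measured in a functional assay on HEK293 cells with D(4) dopamine receptor (Homo sapiens) as the target, read by FLIPR; on this read-out higher numbers stand for larger maximal responses and lower numbers for smaller maximal responses. Compound 1 `CO/N=C(/CCN1CCN(c2ccccn2)CC1)c1ccc(Cl)cc1` gives 68%. Compound 2 `CO/N=C(/CCN1CCN(c2ccccn2)CC1)c1cc(C)cc(C)c1` gives 83% in this assay. Compound 3 `CO/N=C(/CCN1CCN(c2ccccn2)CC1)c1ccc(Cl)cc1Cl` gives 65% in this assay. The steps between them are a number 15 percentage points higher from compound 1 to compound 2 (beyond the scatter), a number 3 percentage points lower from compound 1 to compound 3 (within the scatter) and a number 18 percentage points lower from compound 2 to compound 3 (beyond the scatter). Compound 3 therefore shows the lowest of the three numbers, with compound 1 within the scatter of it and compound 2 beyond the scatter above it.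

Compound 4 `CO/N=C(/CCN1CCN(c2ccccn2)CC1)c1ccc(Cl)c(Cl)c1` has not yet been measured. It differs from compound 3 in this way: 3,4-dichlorophenyl in place of 2,4-dichlorophenyl on a carbon with a double bond to nitrogen. Among the compounds with values here, the only measured step that bears on such a change is a number 3 percentage points lower from compound 1 to compound 3 (within the scatter), where chloro in place of hydrogen on an aromatic carbon left the number within the scatter; the other two steps involve the 3,5-dimethylphenyl compound and do not speak to where chlorine sits. Hence no step beyond the scatter is expected in this assay, and the expected step for compound 4 is a number 1 percentage points higher from compound 3 to compound 4 (within the scatter). Compound 4 is estimated at 66%, with a range from 52% to 80%.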

Compound 4, largest response reached (reported as efficacy), in percent of the reference or control that the assay uses: 63%
For compound 4 the middle estimate is 3 percentage points above the measured one; low and high end bracket the measured number.
By their numbers in this assay, from the lowest: compounds 4, 3 and 1 (each within the scatter of the next); then compound 2.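

In this assay, the two chlorines can sit as in 2,4-dichlorophenyl or as in 3,4-dichlorophenyl with no clear effect on the response (a number 2 percentage points lower from compound 3 to compound 4 (within the scatter)). The second chlorine on the 4-chlorophenyl ring of compound 1 likewise leaves the result within the scatter (a number 5 percentage points lower from compound 1 to compound 4 (within the scatter)), so the three chlorinated compounds cannot be told apart here, while the 3,5-dimethylphenyl compound remains distinct from this new one as well (a number 20 percentage points lower from compound 2 to compound 4 (beyond the scatter)). Nothing available gives a reason for these numbers.

From the compounds shown here alone, it remains open whether the higher response of compound 2 belongs to its methyl groups or to where they sit, and a 3,5-dichlorophenyl ring would separate the two. Going by these compounds, how a methoxy group or a nitrile on the ring would behave also remains unknown.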